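Pinene-derived amines: heteroaryl swap at the amine carbon

This account rests on a few compounds, and the source may have more. Where it says the series, first, only, none or still open, it means among the compounds named here.

The series shares one saturated bicyclic core carrying a secondary amine. Compound 1 `C[C@H]1[C@H](NCc2ccsc2)C[C@H]2C[C@@H]1C2(C)C` bears a thiophen-3-yl on the saturated chain carbon bound to the amine nitrogen; compound 2 `C[C@H]1[C@H](NCc2ccoc2)C[C@H]2C[C@@H]1C2(C)C` bears a furan-3-yl at the same place; compound 3 `Cc1n[nH]cc1CN[C@@H]1C[C@H]2C[C@@H]([C@H]1C)C2(C)C` is not yet measured.

In an ADME assay on MDCK cells (Canis lupus familiaris) for cytotoxicity, read by microscopy, with a stated time of 48 h (on this read-out higher numbers stand for lower toxicity in this test and lower numbers for higher toxicity in this test), compound 1 gives 50000 nM. For compound 2 this assay reports only a limit, > 100000 nM. Among the measured compounds shown here, the one measured step, an at least 2.0-fold higher number from compound 1 to compound 2 (0.30 log units; that floor lies within the scatter), is therefore bounded on one side only, and the limit of > 100000 nM in this assay, at which 1 of the 2 values shown sits, marks where compound 2 sits.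

Compound 3 differs from compound 2 in one place: 3-methyl-1H-pyrazol-4-yl in place of furan-3-yl on a saturated chain carbon bound to an amine nitrogen. For the measured compounds named here, no measured step changes a furan-3-yl into a pyrazolyl, so the single step in hand bears on this change only loosely, and it shows no movement beyond the scatter. For compound 3 the expectation is therefore a number no higher from compound 2 to compound 3 (the limit leaves the size open), a step not beyond the scatter. Compound 3 is estimated at 100000 nM, within 50000 nM to 200000 nM, with a fair chance that this assay again returns only a limit.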

Compound 3, minimum cytotoxic concentration: > 100000 nM
Compound 3 gave a limit, no number; the forecaster's own chance of this, stated with the estimate: 50%; the middle value sits exactly at the limit.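

At the saturated chain carbon bound to an amine nitrogen, a second replacement of the thiophen-3-yl now ends at a limit, with a ring of a different kind: in this assay there is an at least 2.0-fold higher number from compound 1 to compound 3 (0.30 log units; that floor lies within the scatter). The 3-methyl-1H-pyrazol-4-yl brings in ring nitrogen and a hydrogen-bond donor that the furan-3-yl lacks, yet no number appears with either group, so this change does not bring the read-out back into its measurable range. The step from compound 2 to compound 3 cannot be read, and the two groups cannot be ordered, because both compounds stop at the same limit: the limit of > 100000 nM in this assay, at which 2 of the 3 values shown sit.

From the compounds shown here alone, since the floors of both steps from compound 1 lie within the scatter, it remains open whether the thiophen-3-yl truly differs from the other two rings in this test. Also open, going by these compounds, is whether a phenyl ring, or a heteroaryl carrying a carboxylic acid or a primary amine, at this place would give a number rather than a limit.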